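This account rests on a few compounds, and the source may have more. Where it says the series, first, only, none or still open, it means among the compounds named here.

Compound 1 `CCc1cn(COCCO)c(=S)[nH]c1=O` was examined in a functional assay on HepG2 cells (Homo sapiens) for cytotoxicity, read by MTT assay; on this read-out higher numbers stand for lower toxicity in this test and lower numbers for higher toxicity in this test. In this assay compound 1 gives only a limit, > 478000 nM, and no number. Compound 2 `O=c1[nH]c(=O)n(COCCO)cc1C(F)(F)F` likewise reaches only a limit in this assay, > 393000 nM. Compound 1 therefore stands on a limit alone, and the other value shown is a limit as well (the limit of > 393000 nM in this assay, at which 1 of the 2 values shown sits). Compound 3 `CCOC(=O)c1cn(COCCO)c(=S)[nH]c1=O` differs from compound 1 by ethoxycarbonyl in place of ethyl on an aromatic carbon. Among the compounds with values here, no measured step covers this change; with both known values sitting at limits, no shift beyond the scatter is expected in this assay. Compound 3 is expected near 500000 nM, within 200000 nM to 2000000 nM. The expected step that the limit leaves unreadable from compound 1 to compound 3 is estimated to be essentially none.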

Compound 3, half-maximal cytotoxic concentration: > 364000 nM
Compound 3: only a limit was reported (the forecaster's own chance of this, stated with the estimate: 80%); the middle value is on the limit's open side.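

Within the data shown here, compound 1 and compound 3 both give only limits in this assay, so no step between them can be read. Whether ethoxycarbonyl in place of ethyl shifts the result at all stays open, as does the actual position of each compound shown.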